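A few compounds are considered here, and "the series" means these few. Any claim that something is new, unique, unknown or untested is made for them only; others in the source may bear on it.

Values in a functional assay on Jurkat cells (Homo sapiens) for cytotoxicity, with a stated time of 72 h; a higher number here means that more compound is needed for the effect, a lower number that less compound is needed:
Compound 1 `C=C[C@@](C)(/C=C/c1ccc(O)c(/C=C/C(=O)OCC)c1)CCC=C(C)C`: > 49000 nM, a limit.
Compound 2 `C=C[C@@](C)(/C=C/c1ccc(O)c(/C=C/c2ccc(Cl)cc2)c1)CCC=C(C)C`: > 49000 nM, a limit.
Compound 3 `CCOC(=O)/C=C/c1cc(/C=C/[C@](C)(/C=C/c2ccc(OC)cc2)CCC=C(C)C)ccc1O`: > 49000 nM, a limit.

Compound 3 has no number, only the limit > 49000 nM. The whole series stands at the limit of > 49000 nM in this assay, at which 3 of the 3 values shown sit.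

Compound 4 `COc1ccc(/C=C/[C@@](C)(/C=C/c2ccc(O)cc2)CCC=C(C)C)cc1` carries hydrogen in place of 2-(ethoxycarbonyl)ethenyl on an aromatic carbon, ortho to a hydroxy group (hydrogen in place of 2-(ethoxycarbonyl)ethenyl on an aromatic carbon).

The nearest measured change is a step that the two limits leave unreadable from compound 1 to compound 2, on the same chain. The other is a step that the two limits leave unreadable from compound 1 to compound 3, at a different place. Neither gives a size to carry over, so the expectation rests on (the limit of > 49000 nM in this assay, at which 3 of the 3 values shown sit).

In this assay the expected change is small, toward less compound needed, or none: an at least 1.4-fold lower number from compound 3 to compound 4 (0.14 log units; that floor lies within the scatter). Compound 4 is estimated at 35000 nM, with an expected range of 12000 nM to 70000 nM.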

Compound 4, half-maximal effective concentration: > 49000 nM
Compound 4 gave a limit, no number (the forecaster's own chance of this, stated with the estimate: 60%); middle value at least 1.4-fold (0.14 log units) from the limit.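

For the compounds shown here, compound 3 and compound 4 both give only a limit in this assay, so no step between them can be read. The compounds shown leave open which change, if any, would yield a number, as the series stands at: the limit of > 49000 nM in this assay, at which 4 of the 4 values shown sit.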